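The compounds below may be only part of what the source reports. "The series", "measured", "known", "first", "only" and "open" are said of these compounds alone.

Working notes on the series. Compound 1 `O=C(Nc1nc2ccccc2s1)c1cn(-c2ccccc2)nc1-c1ccccc1` and compound 2 `O=C(Nc1nc2ccccc2s1)c1cn(-c2ccccc2)nc1-c1ccc(Cl)cc1` share one core and differ only in the chloro in place of hydrogen on an aromatic carbon. In a functional assay on A549 cells (Homo sapiens) for cytotoxicity, read by MTT assay, with a stated time of 72 h (a higher number here means a weaker inhibitor, a lower number a stronger inhibitor), compound 1 gives 13500 nM, and compound 2 gives 10300 nM, the lower of the two numbers, though the step of a 1.3-fold lower number from compound 1 to compound 2 (0.12 log units; within the scatter) is within the scatter, so the two cannot be ordered.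

Compound 3 `Cc1ccc2nc(NC(=O)c3cn(-c4ccccc4)nc3-c3ccc(Cl)cc3)sc2c1` is not yet measured. It differs from compound 2 by methyl in place of hydrogen on an aromatic carbon. For the measured compounds named here, no measured step touches that ring; the only step available, a 1.3-fold lower number from compound 1 to compound 2 (0.12 log units; within the scatter), sits on a different part of the molecule and was within the scatter, so it gives no direction. On this basis the expected step of a 1.1-fold lower number from compound 2 to compound 3 (0.04 log units; within the scatter) is none beyond the scatter, with the range kept wide for an untested position. Compound 3 is therefore estimated at 9500 nM in this assay, with a range from 4000 nM to 25000 nM.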

Compound 3, half-maximal inhibitory concentration: 18600 nM
Compound 3: middle estimate off by 2.0-fold (0.29 log units), on the low side; measured number inside the range.
By their numbers in this assay, from the lowest: compounds 2, 1 and 3 (each within the scatter of the next).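

For the compounds shown here, the change from 1,3-benzothiazol-2-yl to 6-methyl-1,3-benzothiazol-2-yl gives the first reading at this position, and in this assay the step is a 1.8-fold higher number from compound 2 to compound 3 (0.26 log units; within the scatter) and stays inside the scatter. Methyl on this aromatic carbon therefore does not separate compound 3 from compound 2, just as chloro on the other part of the molecule does not separate its pair in the step of a 1.3-fold lower number from compound 1 to compound 2 (0.12 log units; within the scatter) on the shared core. No measurement offered here bears on why these numbers fall as they do.

As far as these compounds go, whether an amine, a carboxylic acid or a longer chain at this position would move the number beyond the scatter remains open. Also open, from the compounds shown here alone, is how methyl would read on the other carbons of that ring.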